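The source may hold more compounds than are shown below. What is called first, only, known or untested is meant among the compounds shown, and "the series" means these compounds.

Values measured in a functional assay on DU-145 cells (Homo sapiens) for antiproliferative activity, read by MTT assay, with a stated time of 3 days; on this read-out lower numbers stand for stronger inhibition and higher numbers for weaker inhibition:
- compound 1 `CCCS(=O)(=O)Nc1ccc(-c2cc(=O)c3c(O)cc(OC)c(OC(C)C)c3o2)cc1` gives 76900 nM
- compound 2 `COc1cc(O)c2c(=O)cc(-c3ccc(NC(=O)NC4CC4)cc3)oc2c1OC(C)C` gives 15600 nM

Of these two, compound 2 holds the lower number, 15600 nM, and so is the stronger inhibitor of the pair. The next compound to consider is compound 3 `COc1cc(O)c2c(=O)cc(-c3ccc(NC(=O)N4CCCNCC4)cc3)oc2c1OC(C)C`, which keeps the shared core of compound 2 and alters one group: 1,4-diazepan-1-yl in place of cyclopropylamino on a carbonyl carbon. In words, 1,4-diazepan-1-yl takes the place of cyclopropylamino on a carbonyl carbon.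

Within the data shown here, only one measured step can serve as a guide: a 4.9-fold lower number from compound 1 to compound 2 (0.69 log units; beyond the scatter). That modest step swapped propylsulfonyl for cyclopropylcarbamoyl on a nitrogen on an aromatic ring, whereas the new change leaves the carbonyl in place and alters only what sits on it. Among the measured compounds shown here, it therefore bears on the new change only loosely, and no measured pair tests this exact swap. A smaller step than that one seems the fair expectation, probably within the scatter and leaning slightly lower, with the direction uncertain. The expected step is a 1.6-fold lower number from compound 2 to compound 3 (0.19 log units; within the scatter). For compound 3 the estimated value is 10000 nM, with an expected range from 3000 nM to 35000 nM.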

Compound 3, half-maximal inhibitory concentration: 36000 nM
Compound 3: middle estimate off by 3.6-fold (0.56 log units), on the low side; the whole stated range lies below it.
By their numbers in this assay, from the lowest: compound 2; then compound 3; then compound 1.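

Swapping the group on the carbonyl carbon gives in this assay a 2.3-fold higher number from compound 2 to compound 3 (0.36 log units; beyond the scatter) and this modest rise shows that the result at this position depends on what sits on the carbonyl, not on the carbonyl alone: the seven-membered 1,4-diazepan-1-yl ring gives a weaker result here than the small cyclopropylamino group. Compound 3 still keeps part of the gain that the earlier step from the sulfonyl compound had shown, since replacing propylsulfonyl with (1,4-diazepan-1-yl)carbonyl on the nitrogen gives a 2.1-fold lower number from compound 1 to compound 3 (0.33 log units; beyond the scatter) and so both carbonyl-bearing groups give lower numbers than propylsulfonyl in this small set. Nothing at hand accounts for the rise from the cyclopropylamino compound to the diazepane compound.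

Among these compounds, with only two groups on the carbonyl carbon, it remains open whether ring size, the second ring nitrogen or the overall size of the group drives this difference. A six-membered piperazin-1-yl ring, an open-chain dimethylamino group or a longer propylamino chain at the same place would help separate these possibilities.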